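Aryl variation on the shared core: expectation for compound 3

A few compounds are considered here, and "the series" means these few. Any claim that something is new, unique, unknown or untested is made for them only; others in the source may bear on it.

Compound 1 `COc1cc(Br)c(C2C(C#N)=C(N)OC(c3c[nH]c4ccccc34)=C2C#N)cc1OC` and compound 2 `CN(C)c1ccc(C2C(C#N)=C(N)OC(c3c[nH]c4ccccc34)=C2C#N)cc1` share one core and differ only in the aryl group on the saturated ring carbon. In a functional assay, tested at 400 ug/mL (a lower number here means a weaker effect, a higher number a stronger effect of the compound at the concentration tested), compound 1 gives 26.7%. In this assay compound 2 gives 26.7%, level with compound 1 within the scatter, so the two aryl groups tried so far are not told apart here. Compound 3 `N#CC1=C(N)OC(c2c[nH]c3ccccc23)=C(C#N)C1c1ccccc1Cl` carries 2-chlorophenyl in place of 4-(dimethylamino)phenyl on a saturated ring carbon. Within the data shown here, since two quite different aryl groups gave the same read-out and no step in this assay is established, the expected step is a number 0.3 percentage points higher from compound 2 to compound 3 (within the scatter), none beyond the scatter. Compound 3 is estimated at 27% in this assay, within 12% to 45%.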

Compound 3, a percentage reported as activity, at one concentration (the size of the read-out at that concentration, not a potency): 21.4%
Compound 3: the middle estimate sits 5.6 percentage points above what was measured; measured number inside the range.
By their numbers in this assay, from the lowest: compounds 3, 1 and 2 (each within the scatter of the next).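

In this assay, 2-chlorophenyl in place of 4-(dimethylamino)phenyl on the saturated ring carbon gives a number 5.3 percentage points lower from compound 2 to compound 3 (within the scatter) and no step beyond the scatter. Exchanging a nitrogen-bearing aryl group for a chlorine-bearing one therefore still does not separate the compounds at this position. No supporting measurement bears on this result.

Open, from the compounds shown here alone, is whether a group other than aryl here, such as a methyl or a cyclohexyl, or a phenyl carrying a carboxylic acid, would move the read-out. Also open, going by these compounds, is whether replacing the 1H-indol-3-yl group would do so.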